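A few compounds are considered here, and "the series" means these few. Any claim that something is new, unique, unknown or untested is made for them only; others in the source may bear on it.

Measured in a physicochemical assay for lipophilicity; a lower number here means a more polar compound, a higher number a more lipophilic compound:
- compound 1 `CC(C)c1cc(Br)cc(C(C)C)c1O`: 5.49
- compound 2 `CC(C)c1cc([N+](=O)[O-])cc(C(C)C)c1O`: 4.71
- compound 3 `COS(=O)(=O)c1cc(C(C)C)c(O)c(C(C)C)c1`: 3.7

Compound 3 stands lowest of the three in this assay, at 3.7. The next compound up is compound 2, and compound 1 lies furthest away.

The next compound, compound 4 `CC(C)c1cc(CN(C)C)cc(C(C)C)c1O`, keeps the shared core and changes one group: (dimethylamino)methyl in place of methoxysulfonyl on an aromatic carbon, para to a hydroxy group and meta to two isopropyl groups ((dimethylamino)methyl in place of methoxysulfonyl on an aromatic carbon).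

Going by the values given here, three measured steps bear on this place. They are a number 0.78 log units lower from compound 1 to compound 2 (beyond the scatter), a number 1.79 log units lower from compound 1 to compound 3 (beyond the scatter) and a number 1.01 log units lower from compound 2 to compound 3 (beyond the scatter). All three concern a swap of one group at this same carbon, so they show how far such a swap has moved the number here. None of them involves (dimethylamino)methyl, so the data give no direct size for this change.

Compound 3 has the lowest number of the set at 3.7, so an upward move is the likelier direction, and a small one is expected rather than a climb towards compound 1. The expected step is a number 0.30 log units higher from compound 3 to compound 4 (within the scatter). For compound 4 the estimated value is 4, with an expected range from 3.1 to 4.8.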

Compound 4, partition coefficient: 2.5
Compound 4: middle estimate off by 1.50 log units, on the high side; the measured number lies below the stated range.
By their numbers in this assay, from the lowest: compound 4; then compound 3; then compound 2; then compound 1.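

At the aromatic carbon para to a hydroxy group, (dimethylamino)methyl takes this assay lower than any of the three earlier groups, with a number 1.20 log units lower from compound 3 to compound 4 (beyond the scatter) and a number 2.21 log units lower from compound 2 to compound 4 (beyond the scatter) and, as the widest swap yet seen at this carbon, a number 2.99 log units lower from compound 1 to compound 4 (beyond the scatter) in the series. Methoxysulfonyl, the lowest group until now, therefore does not mark the floor at this position, and the lowest number now belongs to a group with one hydrogen-bond acceptor rather than the three of methoxysulfonyl, so the acceptor count does not follow the order of the numbers across this pair. Nothing among the data shown accounts for the size of this fall.

The compounds shown hold no second amine at this carbon, so it stays open whether the fall belongs to the nitrogen as such or to the whole (dimethylamino)methyl group, which an aminomethyl or a morpholinomethyl group would help to separate. As far as these compounds go, how a carboxylic acid, or a longer chain carrying the same dimethylamino end, would stand against compound 4 also remains unknown.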